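This account rests on a few compounds, and the source may have more. Where it says the series, first, only, none or still open, it means among the compounds named here.

Measured compounds:
Compound 1, `CC1=C(C(=O)Nc2ccc([N+](=O)[O-])cc2)C(c2ccc(Br)cc2)N=C(SCc2ccc(F)cc2)N1`, with 32.3% in a functional assay on the whole organism (artery, strain albino) with Rattus norvegicus as the target, with a stated time of 600 min, at a dose of 10 mg/kg by the oral route; on this read-out higher numbers stand for more inhibition at the one dose given (going by the name of the read-out) and lower numbers for less inhibition.
Compound 2, `CC1=C(C(=O)Nc2ccc([N+](=O)[O-])cc2)C(c2cccc([N+](=O)[O-])c2)N=C(SCc2ccccc2Cl)N1`, with 13.3% in this assay.
Compound 3, `CC1=C(C(=O)Nc2ccc([N+](=O)[O-])cc2)C(c2cccc([N+](=O)[O-])c2)N=C(SCc2ccc(Cl)cc2)N1`, with 26.2% in this assay.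

Compound 3 stands second highest of the three numbers. Its nearest neighbour is compound 1, whose number lies within the scatter of it. The other gap is a number 12.9 percentage points higher from compound 2 to compound 3 (beyond the scatter), a change that swaps 4-chlorophenyl for 2-chlorophenyl on a saturated chain carbon bound to a sulfur.

Compound 4, `CC1=C(C(=O)Nc2ccc([N+](=O)[O-])cc2)C(c2cccc([N+](=O)[O-])c2)N=C(SCc2ccc(F)cc2)N1`, is built from compound 3 by a single change: fluoro in place of chloro on an aromatic carbon. Among the measured compounds shown here, no measured pair reproduces this swap alone. Compound 1 already carries the 4-fluorobenzyl group, but it differs from compound 4 in one further place as well, so its value only hints that such a group sits in the same region as compound 3. For the measured compounds named here, the one step that is known, from compound 2 to compound 3, concerns a different change. Swapping one halogen for another on the same aromatic carbon is expected to give no step beyond the scatter, so the step from compound 3 to compound 4 is estimated at a number 1.8 percentage points higher from compound 3 to compound 4 (within the scatter). Compound 4 is therefore expected to show about 28%, between 14% and 42%.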

Compound 4, a percentage reported as inhibition, in the whole organism at one dose (the size of the read-out at that dose, not a potency): 30.3%
Compound 4: middle estimate off by 2.3 percentage points, on the low side; the range from low to high includes it.
By their numbers in this assay, from the lowest: compound 2; then compounds 3, 4 and 1 (each within the scatter of the next).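

Replacing the 4-chlorobenzyl group with the 4-fluorobenzyl group gives a number 4.1 percentage points higher from compound 3 to compound 4 (within the scatter), so in this assay these two halogens cannot be told apart at this place on the ring. The 2-chlorobenzyl group does stand apart, with a number 17 percentage points higher from compound 2 to compound 4 (beyond the scatter), so among these compounds a clear difference appears when the halogen's place changes, not when one halogen replaces the other at the same place. The other aromatic ring can now be compared directly as well: 3-nitrophenyl in place of 4-bromophenyl gives a number 2 percentage points lower from compound 1 to compound 4 (within the scatter), so that exchange also shows no clear difference here.

Nothing available explains why these numbers fall as they do. Still open, on these data alone, is how a non-halogen group at this place, such as an amine or a carboxylic acid, or a longer chain in place of the benzyl group, would read in this whole-animal test.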